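Methoxy to hydroxy on the lowest compound so far

The compounds below may be only part of what the source reports. "The series", "measured", "known", "first", "only" and "open" are said of these compounds alone.

In a functional assay on SGC-7901 cells (Homo sapiens) for antiproliferative activity, read by MTT assay, with a stated time of 72 h (on this read-out higher numbers stand for weaker inhibition and lower numbers for stronger inhibition), compound 3 `COc1ccc(-c2ccc3ncn(-c4cc(OC)c(OC)c(OC)c4)c3c2)cc1` gives 82 nM, the lowest of three numbers, against compound 2 `COc1cc(-n2cnc3ccc(-c4cccc([N+](=O)[O-])c4)cc32)cc(OC)c1OC` at 380 nM and compound 1 `COc1cc(-n2cnc3ccc(-c4cccc(F)c4)cc32)cc(OC)c1OC` at 2490 nM. Compound 4 `COc1cc(-n2cnc3ccc(-c4ccc(O)cc4)cc32)cc(OC)c1OC` departs from compound 3 by hydrogen in place of methyl on an oxygen on an aromatic ring, turning 4-methoxyphenyl into 4-hydroxyphenyl. Going by the values given here, no measured step covers this exact change. The closest evidence comes from swaps of the whole substituted phenyl group: a 6.6-fold lower number from compound 1 to compound 2 (0.82 log units; beyond the scatter), a 4.6-fold lower number from compound 2 to compound 3 (0.67 log units; beyond the scatter) and a 30-fold lower number from compound 1 to compound 3 (1.48 log units; beyond the scatter), all beyond the scatter. With both other groups giving higher numbers, a modest rise is expected in this assay. The estimated step is a 2.4-fold higher number from compound 3 to compound 4 (0.39 log units; beyond the scatter). For compound 4 the expected value is 200 nM, with an estimated range of 60 nM to 700 nM.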

Compound 4, half-maximal inhibitory concentration: > 10000 nM
Compound 4: only a limit was reported; the forecaster's own chance of this, stated with the estimate: 2%; middle value at least 50-fold (1.69 log units) from the limit.
By their numbers in this assay, from the lowest: compound 3; then compound 2; then compound 1. At a limit, above all of these: compound 4.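

Compound 4 gives a limit, not a number, in this assay: the limit of > 10000 nM in this assay, at which 1 of the 4 values shown sits. On this oxygen, hydrogen in place of methyl gives a larger step than any earlier swap of the whole substituted phenyl group, with an at least 120-fold higher number from compound 3 to compound 4 (2.08 log units; beyond the scatter). The 4-hydroxyphenyl group also stands behind both 3-nitrophenyl and 3-fluorophenyl, with an at least 26-fold higher number from compound 2 to compound 4 (1.42 log units; beyond the scatter) and an at least 4.0-fold higher number from compound 1 to compound 4 (0.60 log units; beyond the scatter), so the methyl on this oxygen matters greatly in this series.

Going by these compounds, the full size of these steps remains open. Also open, on these data alone, is whether an ethoxy group or an amine in place of the methoxy would keep the low number of compound 3.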